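Aryl amide variation on a shared core: compound 3

The compounds below may be only part of what the source reports. "The series", "measured", "known", "first", "only" and "open" are said of these compounds alone.

Measured so far in a functional assay on RPMI-8226 cells (Homo sapiens) for inhibition, read by sulforhodamine B assay, tested at 10 uM; on this read-out lower numbers stand for less inhibition and higher numbers for more inhibition at the one concentration tested (going by the name of the read-out):
compound 1, `COc1cc2oc(-c3ccc(NC(=O)c4ccc(C)cc4)cc3)cc(=O)c2c(OC)c1OC`: <= 42.6%
compound 2, `COc1cc2oc(-c3ccc(NC(=O)c4ccc(C(F)(F)F)cc4)cc3)cc(=O)c2c(OC)c1OC`: <= 42.6%

Compound 2 stands only at a limit of this assay, <= 42.6%, not at a number. Compound 1 likewise sits at a limit, <= 42.6%. Among the compounds with values here, the one measured step, a step that the two limits leave unreadable from compound 1 to compound 2, therefore gives no readable size, and the limit of <= 42.6% in this assay, at which 2 of the 2 values shown sit, is all the evidence on this pair.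

Compound 3, `COc1cc2oc(-c3ccc(NC(=O)c4ccc(F)cc4)cc3)cc(=O)c2c(OC)c1OC`, differs from compound 2 by fluoro in place of trifluoromethyl on an aromatic carbon. Within the data shown here, no measured step covers this change, and the step that bears on the same position is unreadable, so no size in this assay can be taken from the series. Compound 3 is estimated to remain at the low end, with a step that the limit leaves unreadable from compound 2 to compound 3 expected as the step, most likely again only a limit. The estimate for compound 3 is 25%, within 0% to 45%.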

Compound 3, a percentage reported as inhibition, at one concentration (the size of the read-out at that concentration, not a potency): <= 42.6%
Compound 3: a limit, no number; the forecaster's own chance of this, stated with the estimate: 75%; the middle value lies beyond the limit too.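

No step among compound 1, compound 2 and compound 3 can be read in this assay, each value being a limit: the limit of <= 42.6% in this assay, at which 3 of the 3 values shown sit.

The compounds shown leave open how far these three differ from one another, and which change at this place, if any, would give a value beyond the limit.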